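This account rests on a few compounds, and the source may have more. Where it says the series, first, only, none or still open, it means among the compounds named here.

Of the compounds shown here, three built on one shared core have been tested in a functional assay on SMMC-7721 cells (Homo sapiens) for cytotoxicity, read by MTT assay, with a stated time of 4 days; on this read-out higher numbers stand for weaker inhibition and lower numbers for stronger inhibition. Compound 1 `C=C1C[C@]23C[C@@]1(O)CC[C@H]2c1cc(Br)c(O)c(C)c1[C@@H]3Cn1cc(-c2ccc(C)cc2)nn1` is one of them. In this assay compound 1 gives > 20000 nM, which is a limit of the assay rather than a number. Compound 2 `C=C1C[C@]23C[C@@]1(O)CC[C@@H]2c1cccc(C)c1[C@@H]3Cn1cc(-c2ccc(OC)cc2)nn1` comes out the same way: in this assay compound 2 gives > 20000 nM, again a limit and not a number. Compound 3 `C=C1C(=O)[C@]23C[C@@]1(O)CC[C@H]2c1ccc(O)c(C)c1[C@@H]3Cn1cc(-c2ccc(Cl)cc2)nn1` differs from both in several places at once; in this assay compound 3 gives 670 nM, a measured number. On the values shown, compound 1 sits at the limit of > 20000 nM in this assay, at which 2 of the 3 values shown sit, where it is not alone.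

Compound 4 `C=C1C[C@]23C[C@@]1(O)CC[C@H]2c1cc(Br)c(O)c(C)c1[C@@H]3Cn1cc(-c2ccc(OC)cc2)nn1` has not yet been measured. It differs from compound 1 in one place only: methoxy in place of methyl on an aromatic carbon. Seen one bond further out, a 4-methylphenyl becomes a 4-methoxyphenyl. Among the compounds with values here, no step between two measured compounds that differ in one place is known here, so the expectation rests on the values alone. Compound 2 already carries the methoxyphenyl and gives a limit, though it differs from compound 1 elsewhere too. The step from compound 1 to compound 4 is expected to be a step that the limit leaves unreadable from compound 1 to compound 4, that is, nothing beyond the scatter. Compound 4 is therefore expected to give 30000 nM, with a likely range from 8000 nM to 100000 nM, most probably as a limit once more.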

Compound 4, half-maximal inhibitory concentration: > 20000 nM
Compound 4: only a limit was reported; the forecaster's own chance of this, stated with the estimate: 70%; the middle value lies beyond the limit too.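

In this assay compound 4 gives > 20000 nM, a limit of the assay and not a number. Compound 1 gives a limit as well, so no step from compound 1 to compound 4 can be read: the limit of > 20000 nM in this assay, at which 3 of the 4 values shown sit.

The compounds shown leave open whether methoxy in place of methyl at this place changes the read-out at all.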